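This account rests on a few compounds, and the source may have more. Where it says the series, first, only, none or still open, it means among the compounds named here.

In an assay on CHO cells for displacement of a labelled ligand from adenosine receptor A1 (Homo sapiens), read by fluorescence, with a stated time of 1 h (a higher number here means a weaker inhibitor, a lower number a stronger inhibitor), three compounds have been measured so far. Compound 1 `CSc1sc(NC(=O)C=C(C)C)nc1C` gives 29500 nM, compound 2 `O=C(Nc1ccc2[nH]ncc2c1)c1ccc[nH]1` gives 3160 nM, and compound 3 `CCc1cc2c(=O)[nH]c(C3CC3)nc2s1` gives 61700 nM. Compound 3 thus stands with the highest number of the three; compound 1 is nearest to it and compound 2 furthest, and both gaps lie beyond the scatter. Compound 4 `CCc1cc2c(=O)[nH]c(-c3ccoc3)nc2s1` differs from compound 3 in one place: furan-3-yl in place of cyclopropyl on an aromatic carbon. Among the compounds with values here, no step between measured compounds speaks to this change, so the expectation rests on compound 3 alone. The step of a 2.1-fold lower number from compound 3 to compound 4 (0.31 log units; beyond the scatter) in this assay is expected to be small and toward a lower number, with no certainty that it clears the scatter. Compound 4 is estimated at 30000 nM, within a range from 8000 nM to 120000 nM.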

Compound 4, inhibition constant: 56200 nM
Beside the measured number, compound 4's estimate is 1.9-fold (0.27 log units) below it; measured number inside the range.
By their numbers in this assay, from the lowest: compound 2; then compounds 1, 4 and 3 (each within the scatter of the next, the first and the last beyond it).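

At this position, on an aromatic carbon between two ring nitrogen atoms, furan-3-yl in place of cyclopropyl gives in this assay a 1.1-fold lower number from compound 3 to compound 4 (0.04 log units; within the scatter) so the two groups cannot be told apart here. A five-membered aromatic ring carrying a hydrogen-bond acceptor and a three-membered carbon ring thus give values within the scatter of each other. Nothing measured here bears on why this is so. The compounds shown leave open whether an amine, a carboxylic acid or a longer chain at this position would move the number beyond the scatter.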